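Aryl sulfonamide series: phenoxy in place of fluoro

The source may report more compounds than this note shows. Statements on the series, on what has been measured and on what is new or still open speak of the compounds shown alone.

Compound 1 `Cc1ccc(NS(=O)(=O)c2cccc(CCCCCCNC(=O)/C=C/c3cccnc3)c2)cc1` gives 6.92 nM
Compound 2 `O=C(/C=C/c1cccnc1)NCCCCCCc1cccc(S(=O)(=O)Nc2ccc(Cl)cc2)c1` gives 24.1 nM
Compound 3 `O=C(/C=C/c1cccnc1)NCCCCCCc1cccc(S(=O)(=O)Nc2ccc(F)cc2)c1` gives 4.28 nM

All three values come from a functional assay on Huh-7 cells (Homo sapiens) for inhibition, read by CCK-8 assay, with a stated time of 72 h (a higher number here means a weaker inhibitor, a lower number a stronger inhibitor), and the compounds differ in one group on the same aromatic carbon. Compound 3 at 4.28 nM cannot be separated from compound 1 at 6.92 nM in this read-out. The gap is a 1.6-fold lower number from compound 1 to compound 3 (0.21 log units; within the scatter) and gives no order between the two. Compound 2 stands apart on both of its steps, a 3.5-fold higher number from compound 1 to compound 2 (0.54 log units; beyond the scatter) and a 5.6-fold lower number from compound 2 to compound 3 (0.75 log units; beyond the scatter) in turn.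

Compound 4 `O=C(/C=C/c1cccnc1)NCCCCCCc1cccc(S(=O)(=O)Nc2ccc(Oc3ccccc3)cc2)c1` has phenoxy in place of fluoro on an aromatic carbon, para to a large group (phenoxy in place of fluoro on an aromatic carbon).

The three measured steps all bear on this change, as they sit at the same carbon, but none of the groups tested there carries a ring. The series therefore offers no direct measure for phenoxy. For the measured compounds named here, the only clear movement away from compound 3 is the one seen for compound 2 at 24.1 nM with chloro, while compound 1 with methyl shows none. A higher number of about that modest size is expected in this assay, with a wide margin. The estimated change is a 7.0-fold higher number from compound 3 to compound 4 (0.85 log units; beyond the scatter) in this read-out. For compound 4 the expected value is 30 nM, within an estimated range of 6 nM to 150 nM in this read-out.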

Compound 4, half-maximal inhibitory concentration: 32.7 nM
For compound 4 the middle estimate is 1.1-fold (0.04 log units) below the measured one, and the stated range covers the measured number.
By their numbers in this assay, from the lowest: compounds 3 and 1 (each within the scatter of the next); then compounds 2 and 4 (each within the scatter of the next).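

In this assay, a group carrying a ring now stands at this aromatic carbon, para to a large group, and the change from fluoro to phenoxy gives a 7.6-fold higher number from compound 3 to compound 4 (0.88 log units; beyond the scatter), while the change from methyl gives a 4.7-fold higher number from compound 1 to compound 4 (0.67 log units; beyond the scatter). The change from chloro gives a 1.4-fold higher number from compound 2 to compound 4 (0.13 log units; within the scatter), so the added ring brings no separation from the chloro compound, and the four groups fall into two sets: fluoro and methyl in compounds 3 and 1 at the lower numbers, chloro and phenoxy in compounds 2 and 4 at the higher ones. Within these four compounds, the number therefore does not rise steadily with the heavy-atom count of the group, and nothing available here accounts for the split into two sets.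

On these data alone, it remains open whether a phenyl, a benzyloxy, a morpholine or an amine at this carbon would fall with the fluoro and methyl set or with the chloro and phenoxy set. As far as these compounds go, it is also open whether a substituent such as methoxy on the outer ring of the phenoxy group would move the number in this assay.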